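A few compounds are considered here, and "the series" means these few. Any claim that something is new, unique, unknown or untested is made for them only; others in the source may bear on it.

The measured compounds in an assay on isolated protein for inhibition of malate dehydrogenase, mitochondrial (Sus scrofa), with stated times of 45 min and 30 min; a higher number here means a weaker inhibitor, a lower number a stronger inhibitor:
Compound 1 `O=S(=O)(Nc1ccc2oc(-c3ccccc3)nc2c1)c1cccs1` gives only a limit, > 63000 nM.
Compound 2 `O=S(=O)(Nc1ccc2oc(-c3ccccc3)nc2c1)c1ccc(O)cc1` gives only a limit, > 63000 nM.
Compound 3 `CS(=O)(=O)Nc1ccc2oc(-c3ccccc3)nc2c1` gives only a limit, > 63000 nM.

Compound 3 thus stands at the limit, as do both of its neighbours. The steps a step that the two limits leave unreadable from compound 1 to compound 2, a step that the two limits leave unreadable from compound 1 to compound 3 and a step that the two limits leave unreadable from compound 2 to compound 3 carry no readable size, since all three values sit at the limit of > 63000 nM in this assay, at which 3 of the 3 values shown sit. Compound 4 `O=S(=O)(Nc1ccc2oc(-c3ccccc3)nc2c1)c1cccc(F)c1` has not yet been measured; it differs from compound 3 by 3-fluorophenyl in place of methyl on a sulfonyl sulfur. Going by the values given here, the steps that bear on this change are those exchanging thiophen-2-yl, 4-hydroxyphenyl and methyl on the sulfonyl sulfur, and none of them is readable, so they give neither size nor direction. Compound 4 is expected to remain at the limit in this assay, estimated at 100000 nM within 30000 nM to 300000 nM. The expected step is a step that the limit leaves unreadable from compound 3 to compound 4.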

Compound 4, half-maximal inhibitory concentration: > 63000 nM
Compound 4 was reported as a limit (the forecaster's own chance of this, stated with the estimate: 85%); the middle value is on the limit's open side.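

No size can be read for the steps linking compound 4 with compound 1, compound 2 and compound 3, because all four compounds rest on the same limit: the limit of > 63000 nM in this assay, at which 4 of the 4 values shown sit.

The compounds shown leave open whether any group on the sulfonyl sulfur gives a measurable value in this assay.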